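Propargyl on the aromatic nitrogen of compound 3

The source may hold more compounds than are shown below. What is called first, only, known or untested is meant among the compounds shown, and "the series" means these compounds.

- compound 1 (`N#Cc1c(-c2ccc(Cl)cc2)cc(-c2ccc(Cl)cc2)n(C(=O)c2ccccc2)c1=O`) gives 2.6 ug/mL
- compound 2 (`N#Cc1c(-c2ccc(Cl)cc2)cc(-c2ccc(Cl)cc2)n([C@@H]2O[C@H](CO)[C@@H](O)[C@H]2O)c1=O`) gives 5.7 ug/mL
- compound 3 (`N#Cc1c(-c2ccc(Cl)cc2)cc(-c2ccc(Cl)cc2)[nH]c1=O`) gives "not active" (no number reported)

In a functional assay on MCF7 cells (Homo sapiens) for cytotoxicity, read by sulforhodamine B assay, with a stated time of 48 h (on this read-out lower numbers stand for stronger inhibition and higher numbers for weaker inhibition), compound 3 is reported as "not active" (no number reported) and so offers no number to step from. The change to compound 4 (`C#CCn1c(-c2ccc(Cl)cc2)cc(-c2ccc(Cl)cc2)c(C#N)c1=O`) is propargyl in place of hydrogen on an aromatic nitrogen (in words, propargyl in place of hydrogen on an aromatic nitrogen). Going by the values given here, the one measured step bearing on it is a 2.2-fold higher number from compound 1 to compound 2 (0.34 log units; beyond the scatter) (one group on that nitrogen exchanged for another), and it is modest. With a group on that nitrogen, compound 1 gives 2.6 ug/mL and compound 2 gives 5.7 ug/mL while compound 3, with hydrogen there, gives no number. Among the compounds with values here, no size of step from compound 3 can be stated. The expected direction is from no number to a measurable value near those two. Propargyl itself is untested in this series, so the range is wide and a report without a number remains possible. In this assay the expected value for compound 4 is 6 ug/mL (estimated range 2 ug/mL to 20 ug/mL).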

Compound 4, half-maximal inhibitory concentration: 16.7 ug/mL
The estimate for compound 4 lay 2.8-fold (0.44 log units) below the measured number; measured number inside the range.
By their numbers in this assay, from the lowest: compound 1; then compound 2; then compound 4.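

In this assay compound 4 gives 16.7 ug/mL, so a measurable number at this aromatic nitrogen does not require benzoyl or the 3,4-dihydroxy-5-(hydroxymethyl)oxolan-2-yl group: propargyl, with no ring, also gives one. The choice of group still shifts the value, with a 2.9-fold higher number from compound 2 to compound 4 (0.47 log units; beyond the scatter) and a 6.4-fold higher number from compound 1 to compound 4 (0.81 log units; beyond the scatter), which places propargyl last of the three groups on this nitrogen in this assay. Steps from compound 3 cannot be read, and no measurement at hand accounts for this order.

Open, as far as these compounds go, is whether a simple methyl or a longer chain such as n-butyl would give a number closer to that of compound 1. Also open, from the compounds shown here alone, is how a chain ending in an amine or a carboxylic acid would compare on this nitrogen.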